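The compounds below may be only part of what the source reports. "The series", "measured", "known", "first", "only" and "open" are said of these compounds alone.

Measured compounds:
- compound 1 `COc1ccc(-c2nc(SCC(=O)c3sc(-c4ccccc4)nc3C)nc(N)c2C#N)cc1`: "not determined" (no result reported)
- compound 2 `COc1ccc(-c2nc(C)c(C(=O)CSc3nc(N)c(C#N)c(-c4ccc(Cl)cc4)n3)s2)cc1`: 39200 nM
- compound 3 `COc1ccc(-c2nc(C)c(C(=O)CSc3nc(N)c(C#N)c(-c4ccccc4)n3)s2)cc1`: "not determined" (no result reported)

Three compounds share the same core and were considered in an ADME assay on HEK293 cells (Homo sapiens) for cytotoxicity, read by MTT assay, with a stated time of 48 h; on this read-out higher numbers stand for weaker inhibition and lower numbers for stronger inhibition. Compound 1 `COc1ccc(-c2nc(SCC(=O)c3sc(-c4ccccc4)nc3C)nc(N)c2C#N)cc1` carries no result there; its entry reads "not determined" (no result reported). Within the data shown here, compound 2 `COc1ccc(-c2nc(C)c(C(=O)CSc3nc(N)c(C#N)c(-c4ccc(Cl)cc4)n3)s2)cc1` is the only one with a number: in this assay compound 2 gives 39200 nM, a weak effect. Compound 3 `COc1ccc(-c2nc(C)c(C(=O)CSc3nc(N)c(C#N)c(-c4ccccc4)n3)s2)cc1` likewise has no number, its entry being "not determined" (no result reported), so compound 3 stands without a place on the scale, beside one further entry of the same kind.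

The step of interest leads from compound 3 to compound 4 `Cc1nc(-c2ccccc2)sc1C(=O)CSc1nc(N)c(C#N)c(-c2ccccc2)n1`. The change is hydrogen in place of methoxy on an aromatic carbon. No step between measured compounds is available, so nothing shown tells how far this change could move the read-out. With only the weak result of compound 2 as a reference, the expectation is a step in this assay of no more than the usual scatter, in no particular direction. Compound 4 is therefore estimated at 40000 nM, within a range from 15000 nM to 100000 nM.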

Compound 4, half-maximal inhibitory concentration: 46700 nM
Beside the measured number, compound 4's estimate is 1.2-fold (0.07 log units) below it, within the range that was stated.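

Among these compounds, with no single number for compound 3 in this assay, no step from compound 3 to compound 4 can be read. The compounds shown leave open how far the change from 4-methoxyphenyl to phenyl moves this read-out. No further data shown bear on the result.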